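Swapping the ring on the carbonyl carbon of a shared core

The source may report more compounds than this note shows. Statements on the series, on what has been measured and on what is new or still open speak of the compounds shown alone.

Compound 1, `COc1cc(-c2cc(/C=C/C(=O)c3ccc(N)cc3)[nH]n2)cc(OC)c1OC`, gives 100% in a functional assay on IGROV-1 cells (Homo sapiens) for cytotoxicity, read by sulforhodamine B assay, with a stated time of 48 h, tested at 1 uM; a higher number here means a weaker effect of the compound at the concentration tested, a lower number a stronger effect.
Compound 2, `COc1cc(-c2cc(/C=C/C(=O)c3ccc(Cl)c(Cl)c3)[nH]n2)cc(OC)c1OC`, gives 99% in this assay.
Compound 3, `COc1ccc(C(=O)/C=C/c2cc(-c3cc(OC)c(OC)c(OC)c3)n[nH]2)cc1`, gives 101% in this assay.

Compound 3 holds the highest of the three numbers, yet the gap from compound 1 is a number 1 percentage points higher from compound 1 to compound 3 (within the scatter) and the gap from compound 2 is a number 2 percentage points higher from compound 2 to compound 3 (within the scatter), so all three compounds sit level at a reading that means essentially no effect at the concentration tested.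

Compound 4, `COc1cc(-c2cc(/C=C/C(=O)c3ccc(F)c(F)c3)[nH]n2)cc(OC)c1OC`, has not yet been measured. It differs from compound 3 in one place: 3,4-difluorophenyl in place of 4-methoxyphenyl on a carbonyl carbon. Going by the values given here, two measured steps bear on this. The step of a number 2 percentage points higher from compound 2 to compound 3 (within the scatter) already exchanged a halogenated ring for the 4-methoxyphenyl at the same carbonyl carbon, and the step of a number 1 percentage points lower from compound 1 to compound 2 (within the scatter) put a 3,4-dichlorophenyl there; neither moved the reading beyond the scatter. Since every ring tried on this carbonyl carbon left the number unchanged, the expected step in this assay is none beyond the scatter, namely a number 1 percentage points lower from compound 3 to compound 4 (within the scatter). Compound 4 is therefore estimated at 100%, with an expected range from 90% to 108%.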

Compound 4, a percentage reported as activity, at one concentration (the size of the read-out at that concentration, not a potency): 95%
The estimate for compound 4 lay 5 percentage points above the measured number, within the range that was stated.
By their numbers in this assay, from the lowest: compounds 4, 2, 1 and 3 (each within the scatter of the next).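

With 3,4-difluorophenyl on the carbonyl carbon, this assay still separates no ring from any other: the reading stays level when this ring takes the place of 4-methoxyphenyl (a number 6 percentage points lower from compound 3 to compound 4 (within the scatter)), 3,4-dichlorophenyl (a number 4 percentage points lower from compound 2 to compound 4 (within the scatter)) or 4-aminophenyl (a number 5 percentage points lower from compound 1 to compound 4 (within the scatter)). The change from chlorine to fluorine on the same ring pattern therefore has no effect that can be told from the scatter, and the same holds for the change from either single-substituted ring. All four compounds now form one level group at this concentration, and nothing in the data gives a reason for that level reading or for the small differences inside it.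

As far as these compounds go, it remains open whether a carboxylic acid on this ring, or a longer chain in place of the ring on the carbonyl carbon, would move the reading beyond the scatter. A reading at one concentration also cannot show whether these four compounds would differ from one another at a higher concentration, where an effect on the cells might first appear.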